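Hydroxymethyl to Methanesulfonamido: What to Expect of Compound 3

This account rests on a few compounds, and the source may have more. Where it says the series, first, only, none or still open, it means among the compounds named here.

Of the compounds shown here, two have so far been tested in a functional assay on the whole organism for inhibition, with Mus musculus as the target, at a dose of 10 mg/kg by the oral route; on this read-out higher numbers stand for more inhibition at the one dose given (going by the name of the read-out) and lower numbers for less inhibition. Compound 1 `CC(C)(C)OC(=O)NCCCCNC(=O)CN1CN(c2ccccc2)C2(CCN(C(=O)c3ccc(C(C)(C)C)cc3)CC2)C1=O` gives 7%, while compound 2 `O=C(CN1CN(c2ccccc2)C2(CCN(C(=O)c3ccc(C4CCCCC4)cc3)CC2)C1=O)NCCCCO` gives 52%, the higher of the two numbers by a gap well beyond the usual scatter of repeated measurements. Compound 3 `CS(=O)(=O)NCCCNC(=O)CN1CN(c2ccccc2)C2(CCN(C(=O)c3ccc(C4CCCCC4)cc3)CC2)C1=O` keeps everything in compound 2 except one change: methanesulfonamido in place of hydroxymethyl on a saturated chain carbon, three bonds along the chain from an amide-type nitrogen. Among the compounds with values here, no measured pair shows what a change of this kind does here, so the expectation rests on compound 2 alone. The estimated step is a number 7 percentage points lower from compound 2 to compound 3 (within the scatter), a modest loss that could still fall inside the scatter. Compound 3 is therefore expected to give about 45%, with a likely range from 15% to 75%.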

Compound 3, a percentage reported as inhibition, in the whole organism at one dose (the size of the read-out at that dose, not a potency): 42%
Beside the measured number, compound 3's estimate is 3 percentage points above it; low and high end bracket the measured number.
By their numbers in this assay, from the lowest: compound 1; then compounds 3 and 2 (each within the scatter of the next).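

In this assay, placing methanesulfonamido on this saturated chain carbon gives a number 10 percentage points lower from compound 2 to compound 3 (within the scatter), so the two groups cannot be told apart by this measurement. This position therefore accepts a larger group containing sulfur and nitrogen without a loss that stands clear of the scatter. No measured evidence is available to explain this result.

Still open, from the compounds shown here alone, is whether a primary amine or a carboxylic acid at this place would also keep the reading in this assay. A longer chain carrying methanesulfonamido is equally untested among the compounds shown.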